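The compounds below may be only part of what the source reports. "The series", "measured", "known", "first", "only" and "open" are said of these compounds alone.

Measured so far:
compound 1 `COc1ccc2[nH]cc(C(=O)/C(C#N)=C/C=C(\Cl)c3ccc(OC)c(OC)c3)c2c1`, giving 58.2% in a functional assay for inhibition, with a stated time of 5 min, tested at 1 mM; a lower number here means less inhibition, a higher number more inhibition at the concentration tested (going by the name of the read-out)
compound 2 `COc1ccc(/C(Cl)=C/C=C(\C#N)C(=O)c2c[nH]c3ccc(Br)cc23)cc1`, giving 62.2% in this assay

Within the data shown here, compound 1 and compound 2 differ in more than one place, so no single step is drawn between them; their two numbers lie within the usual scatter of each other, and compound 1 cannot be set apart from compound 2 on these figures.

Compound 3 `COc1ccc2[nH]cc(C(=O)/C(C#N)=C/C=C(\Cl)c3ccc(Br)cc3)c2c1` is not yet measured. Against compound 1 the change is 4-bromophenyl in place of 3,4-dimethoxyphenyl on a double-bonded chain carbon bound to a chlorine atom and a double-bonded chain carbon. Among the measured compounds shown here, no step involving this change has been measured, so only a small shift, or none beyond the scatter, is expected in this assay. Compound 3 is estimated at 59%, within 42% to 75%, meaning an expected step of a number 0.8 percentage points higher from compound 1 to compound 3 (within the scatter).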

Compound 3, a percentage reported as inhibition, at one concentration (the size of the read-out at that concentration, not a potency): 54.5%
Beside the measured number, compound 3's estimate is 4.5 percentage points above it, within the range that was stated.
By their numbers in this assay, from the lowest: compounds 3, 1 and 2 (each within the scatter of the next).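

At the position on a double-bonded chain carbon bound to a chlorine atom and a double-bonded chain carbon, 4-bromophenyl in place of 3,4-dimethoxyphenyl gives a number 3.7 percentage points lower from compound 1 to compound 3 (within the scatter) in this assay. Among these compounds, this is the first single-place comparison, and on this one pair the exchange of the two aryl groups cannot be told apart from scatter. No measurement at hand bears on why the two groups read alike.

Still open, from the compounds shown here alone, is whether a phenyl carrying an amine or a carboxylic acid at this position would give a step beyond the scatter. Also open, going by these compounds, is what replacing the chlorine atom on that chain carbon would do.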